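This account rests on a few compounds, and the source may have more. Where it says the series, first, only, none or still open, it means among the compounds named here.

Working notes on the series

- compound 1 `COc1cc(/C=C/C(=O)c2cccc(NC(=O)c3c(Cl)cccc3Cl)c2)ccc1O` gives 3.56 ug/mL
- compound 2 `COc1cc(/C=C/C(=O)c2cccc(NC(=O)c3cc(Cl)cc(Cl)c3)c2)ccc1O` gives 17.7 ug/mL
- compound 3 `COc1cc(/C=C/C(=O)c2cccc(NC(=O)c3ccc(Cl)cc3)c2)ccc1O` gives 2.3 ug/mL

In a functional assay on SiHa cells (Homo sapiens) for inhibition (a higher number here means a weaker inhibitor, a lower number a stronger inhibitor), compound 2 is the weakest of the three, at 17.7 ug/mL, and the next question is compound 4 `COC(=O)C(=O)Nc1cccc(C(=O)/C=C/c2ccc(O)c(OC)c2)c1`, not yet measured. The change is methoxycarbonyl in place of 3,5-dichlorophenyl on a carbonyl carbon.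

All three measured steps sit at this same place: a 5.0-fold higher number from compound 1 to compound 2 (0.70 log units; beyond the scatter), a 7.7-fold lower number from compound 2 to compound 3 (0.89 log units; beyond the scatter) and a 1.5-fold lower number from compound 1 to compound 3 (0.19 log units; within the scatter). The first two show that this place can move the number, and both other chlorophenyl groups give lower numbers than the 3,5-dichlorophenyl of compound 2. Every measured compound keeps a chlorophenyl group here, however, so none tests a group without a ring and these steps are only a loose guide.

A modest move towards a lower number in this assay is therefore expected, with wide uncertainty. The expected change is a 2.2-fold lower number from compound 2 to compound 4 (0.34 log units; beyond the scatter). For compound 4 the estimated value is 8 ug/mL, with an expected range of 2.5 ug/mL to 25 ug/mL.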

Compound 4, half-maximal inhibitory concentration: 7.71 ug/mL
The estimate for compound 4 lay 1.0-fold (0.02 log units) above the measured number; low and high end bracket the measured number.
By their numbers in this assay, from the lowest: compounds 3 and 1 (each within the scatter of the next); then compound 4; then compound 2.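

In this assay, going by these compounds alone, the methoxycarbonyl of compound 4 is the first group here without a ring or chlorine, and it gives a 2.3-fold lower number from compound 2 to compound 4 (0.36 log units; beyond the scatter), so a chlorophenyl group on this carbonyl carbon is not needed for a number lower than that of the 3,5-dichlorophenyl group. The same change does not match the other two chlorophenyl groups, with a 3.4-fold higher number from compound 3 to compound 4 (0.53 log units; beyond the scatter) and a 2.2-fold higher number from compound 1 to compound 4 (0.34 log units; beyond the scatter), which places this ringless group inside the range set by the chlorophenyl groups rather than outside it. Nothing available accounts for these differences.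

A single ringless group cannot show whether the number follows the loss of the ring or the ester itself. A carboxylic acid, a primary amide or a longer alkyl chain at this place would separate the two readings.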